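This account rests on a few compounds, and the source may have more. Where it says the series, first, only, none or still open, it means among the compounds named here.

Measured so far:
- compound 1 `Cc1nc(Nc2ccc(Cl)c(Cl)c2)sc1C(=O)/C=C/c1ccccc1`: 22700 nM
- compound 2 `COc1cc(/C=C/C(=O)c2sc(Nc3ccc(Cl)c(Cl)c3)nc2C)cc(OC)c1OC`: > 25000 nM

Two compounds of the series have been run in a functional assay on NCI-H460 cells (Homo sapiens) for cytotoxicity, read by MTT assay; a lower number here means a stronger inhibitor, a higher number a weaker inhibitor. Compound 1 gives 22700 nM in this assay, a weak result. For compound 2 this assay returns only a limit, > 25000 nM, so no number stands for it; it sits at the limit of > 25000 nM in this assay, at which 1 of the 2 values shown sits. Among the compounds with values here, the two compounds differ at the aryl group on the enone, and no step between them can be computed from a limit; what is visible is only that both are weak.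

Compound 3 `COc1cc(/C=C/C(=O)c2sc(Nc3ccc(C)cc3)nc2C)cc(OC)c1OC` is not yet measured. It keeps the core of compound 2 and differs there by 4-methylphenyl in place of 3,4-dichlorophenyl on a nitrogen on an aromatic ring. Within the data shown here, no measured step touches this position, so there is no precedent to scale the change against. With compound 2 at a limit and compound 1 weak, the step from compound 2 to compound 3 in this assay is expected to be small, a number no higher from compound 2 to compound 3 (the limit leaves the size open), in no clear direction beyond the scatter. Compound 3 is therefore expected near 25000 nM, within 8000 nM to 60000 nM, with a real chance that this assay again reports only a limit.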

Compound 3, half-maximal inhibitory concentration: > 25000 nM
Compound 3 ended at the assay's limit; the forecaster's own chance of this, stated with the estimate: 60%; the middle value sits exactly at the limit.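

In this assay, within the data shown here, compound 3 gives > 25000 nM as a limit of the assay, and compound 2 also stands at a limit, so no step between compound 2 and compound 3 can be read. Left open is whether 4-methylphenyl in place of 3,4-dichlorophenyl on a nitrogen on an aromatic ring changes the result in this assay at all.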